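Swapping a carbon ring for an oxazole on the chlorophenyl

The source may report more compounds than this note shows. Statements on the series, on what has been measured and on what is new or still open speak of the compounds shown alone.

Three compounds share one core and differ mainly in the five-membered group carried on the chloro-substituted benzene ring. Compound 1 `Cn1nc2c(=O)n(CC3(O)CCN(Cc4ccc(-c5ccoc5)cc4Cl)CC3)cnc2c1-c1ccc(CN)cc1` gives 177 nM in an assay on isolated protein for inhibition of ubiquitin carboxyl-terminal hydrolase 7 (Homo sapiens), with stated times of 30 min and 2 h; a lower number here means a stronger inhibitor, a higher number a weaker inhibitor. Compound 2 `Cn1nc2c(=O)n(CC3(O)CCN(Cc4ccc(-c5ccco5)cc4Cl)CC3)cnc2c1-c1ccc(C(N)=O)cc1` gives 80.8 nM. Compound 3 `Cn1nc2c(=O)n(CC3(O)CCN(Cc4ccc(C5=CCCC5)cc4Cl)CC3)cnc2c1-c1ccc(CN)cc1` gives 76.9 nM, the lowest number of the three, though compound 2 sits within the scatter of it, so the two cannot be ordered; only compound 1 stands clearly apart.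

Compound 4 `Cn1nc2c(=O)n(CC3(O)CCN(Cc4ccc(-c5ncco5)cc4Cl)CC3)cnc2c1-c1ccc(CN)cc1` has not yet been measured. It differs from compound 3 in one place: 1,3-oxazol-2-yl in place of cyclopent-1-en-1-yl on an aromatic carbon.

Among the measured compounds shown here, one measured step bears on this. Going from a five-membered aromatic ring with one hetero atom to the carbon-only ring gave a 2.3-fold lower number from compound 1 to compound 3 (0.36 log units; beyond the scatter). Compound 4 moves back to a five-membered aromatic ring, now with two hetero atoms, so a modest rise toward the number of compound 1 is expected, roughly a 1.8-fold higher number from compound 3 to compound 4 (0.26 log units; within the scatter). Compound 4 is therefore estimated at 140 nM, with a likely range from 60 nM to 350 nM.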

Compound 4, half-maximal inhibitory concentration: 1120 nM
The estimate for compound 4 lay 8.0-fold (0.90 log units) below the measured number, outside the stated range (above it).
By their numbers in this assay, from the lowest: compounds 3 and 2 (each within the scatter of the next); then compound 1; then compound 4.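

Replacing cyclopent-1-en-1-yl with 1,3-oxazol-2-yl, a ring of the same size, gives a 15-fold higher number from compound 3 to compound 4 (1.16 log units; beyond the scatter), so ring size alone does not set the number at this position. Being a five-membered aromatic ring does not settle it either: 1,3-oxazol-2-yl in place of furan-3-yl gives a 6.3-fold higher number from compound 1 to compound 4 (0.80 log units; beyond the scatter), so these two aromatic rings cannot be treated as interchangeable here. Nothing available explains why the oxazole gives the highest number of the series.

The furan-3-yl to 1,3-oxazol-2-yl change alters both the number of hetero atoms and their arrangement, and the compounds shown cannot separate those two changes. From the compounds shown here alone, it also remains open where a saturated cyclopentyl ring or a thiazol-2-yl ring would fall on this same core.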